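The source may report more compounds than this note shows. Statements on the series, on what has been measured and on what is new or still open speak of the compounds shown alone.

Measured in an assay on isolated protein for inhibition of Indoleamine 2,3-dioxygenase 1 (Homo sapiens), read by fluorescence, with a stated time of 60 min; on this read-out higher numbers stand for weaker inhibition and lower numbers for stronger inhibition:
compound 1 `NS(=O)(=O)NNc1nonc1/C(=N/O)Nc1ccc(F)c(Br)c1` gives 218 nM
compound 2 `O=S1(=O)CC(Nc2nonc2/C(=N/O)Nc2ccc(F)c(Br)c2)C1` gives 99 nM
compound 3 `C#CCNS(=O)(=O)CCNc1nonc1/C(=N/O)Nc1ccc(F)c(Br)c1` gives 218 nM

Compound 3 stands level with compound 1 at the digits shown, the two together the highest numbers of the three; the only step from compound 3 beyond the scatter is a 2.2-fold higher number from compound 2 to compound 3 (0.34 log units; beyond the scatter). Compound 4 `NNS(=O)(=O)CCNc1nonc1/C(=N/O)Nc1ccc(F)c(Br)c1` differs from compound 3 by amino in place of propargyl on a sulfonamide nitrogen. The measured step that bears on this is no change at the digits printed from compound 1 to compound 3 (within the scatter), where the whole substituent on the aromatic nitrogen was exchanged, sulfamoylamino against the propargyl-bearing chain, and the number did not move. Given that larger exchange read as no change, the smaller trimming to amino is expected to give no step beyond the scatter in this assay, compound 4 expected at a 1.1-fold lower number from compound 3 to compound 4 (0.04 log units; within the scatter). Compound 4 is therefore estimated at 200 nM, range 100 nM to 450 nM.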

Compound 4, half-maximal inhibitory concentration: 135 nM
Estimate against measurement, compound 4: 1.5-fold (0.17 log units) above, and the stated range covers the measured number.
By their numbers in this assay, from the lowest: compounds 2, 4, 1 and 3 (each within the scatter of the next, the first and the last beyond it).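

In this assay amino in place of propargyl on a sulfonamide nitrogen stays within the scatter (a 1.6-fold lower number from compound 3 to compound 4 (0.21 log units; within the scatter)), so this end of the chain has shown no readable step for this change. Compound 4 also lies within the scatter of the other two (a 1.4-fold higher number from compound 2 to compound 4 (0.13 log units; within the scatter); a 1.6-fold lower number from compound 1 to compound 4 (0.21 log units; within the scatter)), although compound 2 and compound 3 are separated beyond it. No supporting data explain these numbers.

Open, from the compounds shown here alone, is whether a carboxylic acid or a longer alkyl chain on that sulfonamide nitrogen would give a step beyond the scatter.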